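This account rests on a few compounds, and the source may have more. Where it says the series, first, only, none or still open, it means among the compounds named here.

Working notes, series in a functional assay on cells (Cancer cell lines, Homo sapiens) for inhibition; a higher number here means a weaker inhibitor of growth, a lower number a stronger inhibitor of growth:

- compound 1 `Cc1cn2c(/C=N/Nc3ccccn3)c(-c3ccc(Cl)c([N+](=O)[O-])c3)nc2s1`: 11700 nM
- compound 2 `N=C(N)N/N=C/c1c(-c2cc(Cl)sc2Cl)nc2n1CCS2`: 8130 nM
- compound 3 `N=C(N)N/N=C/c1c(-c2cccs2)nc2sccn12`: 12300 nM

Compound 2, at 8130 nM, lies within the scatter of both compound 1 and compound 3, so the three measured compounds cannot be ranked in this assay.

The next compound is compound 4 `N=C(N)N/N=C/c1c(-c2cccs2)nc2n1CCS2`. Relative to compound 2 it carries thiophen-2-yl in place of 2,5-dichlorothiophen-3-yl on an aromatic carbon.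

For the measured compounds named here, no two measured compounds differ in one place, so the size of this change has no direct precedent. The closest guide is compound 3, which also carries thiophen-2-yl and gives 12300 nM. That value is within the scatter of compound 2, so no change beyond the scatter is expected in this assay.

The expected change is a 1.4-fold higher number from compound 2 to compound 4 (0.13 log units; within the scatter), with no firm direction. For compound 4 the estimated value is 11000 nM, with an expected range of 5000 nM to 28000 nM.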

Compound 4, concentration for 50% growth inhibition: 19500 nM
Beside the measured number, compound 4's estimate is 1.8-fold (0.25 log units) below it; the range from low to high includes it.
By their numbers in this assay, from the lowest: compounds 2, 1, 3 and 4 (each within the scatter of the next, the first and the last beyond it).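

For the compounds shown here, replacing 2,5-dichlorothiophen-3-yl with thiophen-2-yl on this aromatic carbon gives a 2.4-fold higher number from compound 2 to compound 4 (0.38 log units; beyond the scatter) in this assay, the first single-place step and the first comparison to clear the scatter. The group at this position therefore has a modest but readable effect on growth inhibition on this core, with the dichlorinated group giving the lower number in this one pair. No supporting data bear on the reason for this difference.

The change removes both chlorine atoms and also alters the thiophene attachment, so the pair cannot separate the contribution of the chlorines from that of the attachment point. Unsubstituted thiophen-3-yl or a monochlorinated thiophene would divide the step, and a phenyl ring would test whether a thiophene is needed here at all.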